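A few compounds are considered here, and "the series" means these few. Any claim that something is new, unique, unknown or untested is made for them only; others in the source may bear on it.

Compound 1 `O=C1c2c[n+]([O-])c3ccccc3c2C(=O)c2c1c1ccccc1n2Cc1cn([C@H]2C[C@H](O)[C@@H](CO)O2)nn1`: 580 nM
Compound 2 `O=C1c2c[n+]([O-])c3ccccc3c2C(=O)c2c1c1ccccc1n2CCN1CCCCC1`: 1050 nM
Compound 3 `O=C1c2c[n+]([O-])c3ccccc3c2C(=O)c2c1c1ccccc1n2Cc1cn(C[C@@H](O)CO)nn1`: not yet measured

The read-out throughout is a functional assay on MDA-MB-231 cells (Homo sapiens) for cytotoxicity, read by MTT assay, with a stated time of 72 h; on this read-out lower numbers stand for stronger inhibition and higher numbers for weaker inhibition. In this assay compound 2 gives 1050 nM, and compound 1 gives 580 nM; these two values lie within the scatter of each other, so they cannot be ranked.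

Compound 3 differs from compound 2 as follows: 1-(2,3-dihydroxypropyl)-1H-1,2,3-triazol-4-yl in place of (piperidin-1-yl)methyl on a saturated chain carbon bound to an aromatic nitrogen. In words, 1-(2,3-dihydroxypropyl)-1H-1,2,3-triazol-4-yl stands in place of (piperidin-1-yl)methyl on a saturated chain carbon bound to an aromatic nitrogen.

Going by the values given here, no step between measured compounds is available to size this change. Among the compounds with values here, the only guide is the narrow spread of the two measured values, so no step beyond the scatter is expected in this assay, and no firm direction can be given. The estimated step is a 1.3-fold lower number from compound 2 to compound 3 (0.12 log units; within the scatter). For compound 3 the expected value is 800 nM, with an estimated range of 300 nM to 2100 nM.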

Compound 3, half-maximal inhibitory concentration: 670 nM
The estimate for compound 3 lay 1.2-fold (0.08 log units) above the measured number; the measured number falls inside the stated range.
By their numbers in this assay, from the lowest: compounds 1, 3 and 2 (each within the scatter of the next).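

In this assay the entry of 1-(2,3-dihydroxypropyl)-1H-1,2,3-triazol-4-yl in place of (piperidin-1-yl)methyl on a saturated chain carbon bound to an aromatic nitrogen gives a 1.6-fold lower number from compound 2 to compound 3 (0.20 log units; within the scatter) and so leaves the number within the scatter. On the aromatic nitrogen of the triazole, 2,3-dihydroxypropyl in place of 4-hydroxy-5-(hydroxymethyl)oxolan-2-yl gives a 1.2-fold higher number from compound 1 to compound 3 (0.06 log units; within the scatter) and thus shows that the oxolane ring can give way to this open chain with no readable change in this read-out. No measurement bearing on the reason for either result is available.

Still open, going by these compounds, is whether a carboxylic acid or a primary amine at the end of this chain would move the number beyond the scatter. On these data alone, the opposite stereocentre of the 2,3-dihydroxypropyl group also remains open.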